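The compounds below may be only part of what the source reports. "The series", "measured", "known", "first", "only" and "open" are said of these compounds alone.

In an ADME assay on NIH3T3 cells (Mus musculus) for cytotoxicity, read by MTT assay, with a stated time of 24 h (on this read-out lower numbers stand for stronger inhibition and higher numbers for weaker inhibition), compound 2 `O=C(CSc1nnc(-c2ccncc2)o1)N/N=C/c1ccccc1O` gives 155000 nM, and compound 1 `O=C(CSc1nnc(-c2ccncc2)o1)N/N=C/c1cccc(F)c1` gives 205000 nM; the two numbers lie within the scatter of each other, as a 1.3-fold lower number from compound 1 to compound 2 (0.12 log units; within the scatter) shows. Compound 3 `O=C(CSc1nnc(-c2ccncc2)o1)N/N=C/c1ccc(O)c(O)c1` differs from compound 2 by 3,4-dihydroxyphenyl in place of 2-hydroxyphenyl on a carbon with a double bond to nitrogen. Going by the values given here, the only measured step that bears on this change is likewise a swap of the aromatic group on that carbon, and it brought nothing beyond the scatter, so compound 3 is expected to shift by a 1.0-fold higher number from compound 2 to compound 3 (0.01 log units; within the scatter), staying within the scatter. Compound 3 is therefore estimated at 160000 nM, with a range from 60000 nM to 420000 nM.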

Compound 3, half-maximal inhibitory concentration: 154000 nM
Beside the measured number, compound 3's estimate is 1.0-fold (0.02 log units) above it; measured number inside the range.
By their numbers in this assay, from the lowest: compounds 3, 2 and 1 (each within the scatter of the next).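

Three different aromatic groups on the carbon with a double bond to nitrogen now lie within the scatter of one another in this assay. Placing 3,4-dihydroxyphenyl there gives a 1.0-fold lower number from compound 2 to compound 3 (0.00 log units; within the scatter) and a 1.3-fold lower number from compound 1 to compound 3 (0.12 log units; within the scatter), so neither comparison separates it from the earlier groups. No separate measurement offers an explanation for this result. Still open, on these data alone, is whether an amine, a carboxylic acid or a longer chain at this position would move the number beyond the scatter.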